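Swapping the Chain Amine on the Weaker Compound

The compounds below may be only part of what the source reports. "The series", "measured", "known", "first", "only" and "open" are said of these compounds alone.

Among the compounds with values here, compound 2 `COc1ccc(-n2nc(C(=O)Nc3ccc(Oc4ccnc5cc(OCCCN6CCCC6)c(OC)cc45)c(F)c3)c(C)cc2=O)cc1` gives 3610 nM in a functional assay on NCI-H460 cells (Homo sapiens) for inhibition, read by MTT assay, with a stated time of 72 h (a higher number here means a weaker inhibitor, a lower number a stronger inhibitor), the higher of the two numbers known here. Within the data shown here, compound 1 `COc1cc2c(Oc3ccc(NC(=O)c4nn(-c5ccccc5C(F)(F)F)c(=O)cc4C)cc3F)ccnc2cc1OCCCN1CCN(C)CC1` gives 240 nM in this assay, a gap to compound 2 that lies beyond the scatter; the two structures differ in more than one place, so no single step joins them. Compound 3 `COc1ccc(-n2nc(C(=O)Nc3ccc(Oc4ccnc5cc(OCCCN6CCN(C)CC6)c(OC)cc45)c(F)c3)c(C)cc2=O)cc1` is compound 2 with 4-methylpiperazin-1-yl in place of pyrrolidin-1-yl on a saturated chain carbon, three bonds along the chain from an oxygen on an aromatic ring. Among the measured compounds shown here, no measured pair isolates this change. The step of a 1.4-fold lower number from compound 2 to compound 3 (0.16 log units; within the scatter) is expected to stay within the scatter, in either direction. Compound 3 is estimated at 2500 nM, within a range of 800 nM to 8000 nM.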

Compound 3, half-maximal inhibitory concentration: 3660 nM
Beside the measured number, compound 3's estimate is 1.5-fold (0.17 log units) below it, within the range that was stated.
By their numbers in this assay, from the lowest: compound 1; then compounds 2 and 3 (each within the scatter of the next).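

In this assay the change to 4-methylpiperazin-1-yl from pyrrolidin-1-yl gives a 1.0-fold higher number from compound 2 to compound 3 (0.01 log units; within the scatter) and so, for these two amines on the 4-methoxyphenyl series, leaves the number within the scatter at this chain position. Within the data shown here, compound 3 also gives the first single-place comparison with compound 1: 4-methoxyphenyl in place of 2-(trifluoromethyl)phenyl on the aromatic nitrogen gives a 15-fold higher number from compound 1 to compound 3 (1.18 log units; beyond the scatter) and is a large step. Nothing measured here explains either step.

From the compounds shown here alone, whether morpholin-4-yl on the same chain would also stay within the scatter remains open. So does the effect of pyrrolidin-1-yl when 2-(trifluoromethyl)phenyl sits on the aromatic nitrogen.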